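The source may report more compounds than this note shows. Statements on the series, on what has been measured and on what is new or still open speak of the compounds shown alone.

Measured so far:
Compound 1, `CCOC(=O)c1c(-c2c(Cl)c3cc(C)ccc3oc2=O)nn(-c2ccccc2)c1C(=O)OCC`, gives 228000 nM in a functional assay on HeLa cells (Homo sapiens) for cytotoxicity, read by MTT assay, with a stated time of 48 h; on this read-out lower numbers stand for stronger inhibition and higher numbers for weaker inhibition.
Compound 2, `CCOC(=O)c1c(-c2c(Cl)c3cc(C)ccc3oc2=O)nn(-c2cccc(C)c2)c1C(=O)OCC`, gives 115000 nM in this assay.
Compound 3, `CCOC(=O)c1c(-c2cc3ccccc3oc2=O)nn(-c2cccc(C)c2)c1C(=O)OCC`, gives 245000 nM in this assay.

Compounds 1 and 2 share one core and differ in a single place: methyl in place of hydrogen on an aromatic carbon. That change made the step of a 2.0-fold lower number from compound 1 to compound 2 (0.30 log units; within the scatter). Compound 3 carries a different core, and the difference between the two cores is not broken down here. Its number in this assay is close to that of compound 1, while compound 2 stands at a lower number than compound 3 by a gap that lies beyond the scatter.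

Compound 4, `CCOC(=O)c1c(-c2cc3ccccc3oc2=O)nn(-c2ccc(C)c(C)c2)c1C(=O)OCC`, is not yet measured. For the measured compounds named here, it comes from compound 3 by a change of the same kind as the one from compound 1 to compound 2: methyl in place of hydrogen on an aromatic carbon. The place is not the same, though. In the earlier pair the methyl entered meta to a large group; here it enters ortho to a methyl group and para to a large group.

Going by the values given here, with only one earlier example of this kind of change, and that one within the scatter, the expected step for compound 4 in this assay is a 1.4-fold lower number from compound 3 to compound 4 (0.16 log units; within the scatter), which rests on compound 3 giving 245000 nM and on the earlier step of a 2.0-fold lower number from compound 1 to compound 2 (0.30 log units; within the scatter). On that basis compound 4 is estimated at 170000 nM, expected to fall between 70000 nM and 400000 nM.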

Compound 4, half-maximal inhibitory concentration: 50000 nM
Compound 4: middle estimate off by 3.4-fold (0.53 log units), on the high side, and the stated range ends above it.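

Adding one more methyl to the aromatic ring, which turns 3-methylphenyl into 3,4-dimethylphenyl, gives a 4.9-fold lower number from compound 3 to compound 4 (0.69 log units; beyond the scatter) in this assay. For the compounds shown here, the same kind of change therefore moved the number in the same direction on both cores, and the two steps cannot be told apart in size: the same change on two cores in this assay, a 2.0-fold lower number (0.30 log units; within the scatter) from compound 1 to compound 2 and a 4.9-fold lower number (0.69 log units; beyond the scatter) from compound 3 to compound 4, 2.5-fold (0.39 log units) apart, within the scatter of two such steps This does not show that the change carries over from one core to another with a fixed size, as only two pairs are available, only the newer step stands clear of the scatter on its own, and the methyl enters at a different place in each pair, so an influence of the core cannot be separated from an influence of the place.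

It remains open whether a methyl is needed at all, as no other group appears at this place on the ring in the compounds shown, such as a chlorine, a methoxy group or a longer chain like ethyl. Also open, on these data alone, is what 3,4-dimethylphenyl would give on the core of compound 1, which would compare the same place on both cores.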